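This account rests on a few compounds, and the source may have more. Where it says the series, first, only, none or still open, it means among the compounds named here.

Measured compounds in an ADME assay on Vero cells (Chlorocebus sabaeus) for cytotoxicity, read by MTT assay, with a stated time of 24 h; a lower number here means that less compound is tolerated, a higher number that more compound is tolerated:
compound 1 `COc1ccc(-n2c(SC(C)C(=O)Nc3nc(C)c(Br)cc3Br)nc3ccccc32)cc1`, value 9700 nM;
compound 2 `COc1ccc(-n2c(SC(C)C(=O)Nc3ncc(C(F)(F)F)cc3Cl)nc3ccccc32)cc1`, value 9200 nM;
compound 3 `Cc1ccc(NC(=O)C(C)Sc2nc3ccccc3n2Cc2ccccc2)c(Cl)c1`, see below.

Compound 3 reports only a limit in this assay, namely > 75000 nM, so its position on the scale is not fixed. Compound 4 `COc1ccc(-n2c(SC(C)C(=O)Nc3ccc(C)cc3Cl)nc3ccccc32)cc1` is not yet measured. It differs from compound 3 by 4-methoxyphenyl in place of benzyl on an aromatic nitrogen. Among the measured compounds shown here, no measured step covers this change; the only measured step, a 1.1-fold lower number from compound 1 to compound 2 (0.02 log units; within the scatter), alters the amide-side group instead. Compound 1 and compound 2 both carry the entering 4-methoxyphenyl group and fall close together in this assay, while compound 3 with benzyl sits at the limit (the limit of > 75000 nM in this assay, at which 1 of the 3 values shown sits). Compound 4 is therefore expected to move toward the values of compound 1 and compound 2, giving an at least 3.7-fold lower number from compound 3 to compound 4 (0.57 log units; beyond the scatter). The estimate for compound 4 in this assay is 20000 nM, between 7000 nM and 75000 nM.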

Compound 4, half-maximal cytotoxic concentration: > 75000 nM
Compound 4: only a limit was reported; the forecaster's own chance of this, stated with the estimate: 30%; middle value at least 3.7-fold (0.57 log units) from the limit.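

In this assay compound 4 reports only a limit, > 75000 nM, so 4-methoxyphenyl on the aromatic nitrogen does not by itself bring the number down to the level of the halogenated pyridinyl amides. With 4-methoxyphenyl held, the amide-side group makes the readable difference, with 2-chloro-4-methylphenyl giving an at least 8.1-fold higher number from compound 2 to compound 4 (0.91 log units; beyond the scatter) and an at least 7.7-fold higher number from compound 1 to compound 4 (0.88 log units; beyond the scatter). Compound 3 and compound 4 are both limits, so the step between them cannot be read: the limit of > 75000 nM in this assay, at which 2 of the 4 values shown sit.

Open, as far as these compounds go, is whether benzyl with a halogenated pyridinyl amide group also stays at the limit. Also open, from the compounds shown here alone, is what an amine or a carboxylic acid in place of the methoxy group would do.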